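Swapping benzoyl for cyclopentylsulfonyl on a shared core

This account rests on a few compounds, and the source may have more. Where it says the series, first, only, none or still open, it means among the compounds named here.

Compound 1 `COc1ccc(-c2cn3cc(C4=CCN(S(=O)(=O)CCc5ccccc5)CC4)ccc3n2)cc1OC`, compound 2 `COc1ccc(-c2cn3cc(C4=CCN(C(=O)C(C)(C)C)CC4)ccc3n2)cc1OC` and compound 3 `COc1ccc(-c2cn3cc(C4=CCN(C(=O)c5ccccc5)CC4)ccc3n2)cc1OC` share one core and differ only in the group on an amine nitrogen in a ring. In a functional assay on A549 cells (Homo sapiens) for antiproliferative activity, read by MTT assay, with a stated time of 48 h (on this read-out higher numbers stand for weaker inhibition and lower numbers for stronger inhibition), compound 1 gives 7690 nM. In this assay compound 2 gives 4340 nM, and compound 3 gives 7700 nM. Compound 3 lies within the usual scatter of both other compounds, so the three cannot be ranked.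

Compound 4 `COc1ccc(-c2cn3cc(C4=CCN(S(=O)(=O)C5CCCC5)CC4)ccc3n2)cc1OC` carries cyclopentylsulfonyl in place of benzoyl on an amine nitrogen in a ring. For the measured compounds named here, no measured compound carries this exact group. The closest measured change links a sulfonyl group to benzoyl, namely phenethylsulfonyl replaced by benzoyl, a 1.0-fold higher number from compound 1 to compound 3 (0.00 log units; within the scatter). The two other changes at this nitrogen, a 1.8-fold lower number from compound 1 to compound 2 (0.25 log units; within the scatter) and a 1.8-fold higher number from compound 2 to compound 3 (0.25 log units; within the scatter), also stay within the scatter. With all three steps this small, no step beyond the scatter is expected in this assay.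

The estimated change is only a 1.2-fold lower number from compound 3 to compound 4 (0.07 log units; within the scatter), which would stay within the scatter. For compound 4 the expected value is 6500 nM, with an estimated range from 3000 nM to 14000 nM.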

Compound 4, half-maximal inhibitory concentration: 6470 nM
Compound 4: the middle estimate sits 1.0-fold (0.00 log units) above what was measured; measured number inside the range.
By their numbers in this assay, from the lowest: compounds 2, 4, 1 and 3 (each within the scatter of the next).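

Cyclopentylsulfonyl gives this nitrogen a second sulfonyl group, so two groups on the sulfonyl sulfur can now be compared directly in this assay, and cyclopentyl in place of phenethyl leaves the result within the scatter (a 1.2-fold lower number from compound 1 to compound 4 (0.08 log units; within the scatter)). The swap from benzoyl is also informative, as the same count of heavy atoms enters and leaves while a six-membered aromatic ring gives way to a five-membered non-aromatic one and a carbonyl gives way to a sulfonyl, yet the step stays within the scatter (a 1.2-fold lower number from compound 3 to compound 4 (0.08 log units; within the scatter)), as does the step from the (tert-butyl)carbonyl group (a 1.5-fold higher number from compound 2 to compound 4 (0.17 log units; within the scatter)). Across these four compounds, neither the type of link to the nitrogen nor the type of ring on it separates the values, and no supporting data are available to explain this.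

On these data alone, it remains open whether a group carrying an amine or a carboxylic acid on this nitrogen, or a simple methylsulfonyl group, would give a step beyond the scatter. All four compounds also keep the shared core, so they cannot show whether a change elsewhere on it would matter more than changes at this nitrogen.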